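Swapping the alkyne-linked ring in a kinase inhibitor series

The compounds below may be only part of what the source reports. "The series", "measured", "known", "first", "only" and "open" are said of these compounds alone.

Measured compounds:
compound 1, `C=Cc1ccnc(C#Cc2ccc3ncn(-c4ccnc(N)n4)c3c2)c1`, 1580 nM
compound 2, `C#Cc1cccc(C#Cc2ccc3ncn(-c4ccnc(N)n4)c3c2)n1`, 3160 nM
compound 3, `C#Cc1cncc(C#Cc2ccc3ncn(-c4ccnc(N)n4)c3c2)c1`, 63100 nM

These three compounds share a core and differ only in the aromatic ring attached to the triple bond. In an assay on Sf9 cells for inhibition of mitogen-activated protein kinase kinase kinase 14 variant S549D (Homo sapiens), with a stated time of 30 min, in the presence of a further agent that is not named here (on this read-out higher numbers stand for weaker inhibition and lower numbers for stronger inhibition), compound 3 gives 63100 nM, the highest number of the three; its nearest neighbour is compound 2 with 3160 nM, and compound 1 gives 1580 nM. The steps show a 40-fold higher number from compound 1 to compound 3 (1.60 log units; beyond the scatter) and a 20-fold higher number from compound 2 to compound 3 (1.30 log units; beyond the scatter), both large, whereas a 2.0-fold higher number from compound 1 to compound 2 (0.30 log units; within the scatter).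

Compound 4, `C=Cc1ccnc(C#Cc2ccc3ncn(-c4ccnc(N)n4)c3c2)n1`, has not yet been measured in this assay. Relative to compound 3 the change is a group of 8 heavy atoms (6 carbon, 2 nitrogen; one six-membered aromatic ring with 2 hetero atoms) in place of a group of 8 heavy atoms (7 carbon, 1 nitrogen; one six-membered aromatic ring with 1 hetero atom), on a triple-bonded carbon. The two large steps, from compound 1 and from compound 2 to compound 3, show that exchanging this ring can move the number substantially, and compound 4 carries the double bond outside aromatic rings that compound 1 also bears. The step from compound 3 to compound 4 is therefore expected to be a large decrease, a 32-fold lower number from compound 3 to compound 4 (1.50 log units; beyond the scatter), bringing compound 4 back toward the numbers of compounds 1 and 2. Compound 4 is estimated at 2000 nM, with a range from 500 nM to 8000 nM.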

Compound 4, half-maximal inhibitory concentration: 1580 nM
For compound 4 the middle estimate is 1.3-fold (0.10 log units) above the measured one; measured number inside the range.
By their numbers in this assay, from the lowest: compounds 1, 4 and 2 (each within the scatter of the next); then compound 3.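

The ring with 2 hetero atoms is tolerated at this triple-bonded carbon: with the double bond outside aromatic rings present in both compounds, the ring exchange gives no change at the digits printed from compound 1 to compound 4 (within the scatter), so the added ring hetero atom and hydrogen-bond acceptor leave the number where it stood. The recovery from the outlying compound is large, at a 40-fold lower number from compound 3 to compound 4 (1.60 log units; beyond the scatter), while the comparison with the other compound bearing a different ring gives a 2.0-fold lower number from compound 2 to compound 4 (0.30 log units; within the scatter), which leaves compounds 1, 2 and 4 together and compound 3 alone at the high end. Since compound 2 carries a triple bond outside aromatic rings as compound 3 does and still sits with compounds 1 and 4, that bond alone does not set compound 3 apart, and nothing available explains why the ring of compound 3 gives so high a number.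

The compounds shown leave open whether the number would stay in this range with an amine, a carboxylic acid or a longer chain on the ring in place of the double-bonded group. They also leave open whether a ring with 2 hetero atoms carrying a triple bond outside aromatic rings would match compound 4 or compound 3.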